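Methylamino to dimethylamino against a limit

A few compounds are considered here, and "the series" means these few. Any claim that something is new, unique, unknown or untested is made for them only; others in the source may bear on it.

Measured in a functional assay on A549 cells (Homo sapiens), read by MTT assay, with a stated time of 72 h (on this read-out higher numbers stand for weaker inhibition and lower numbers for stronger inhibition), all as limits:
- Compound 1 `CSc1ncnc2c1c(-c1ccsc1)cn2[C@@H]1O[C@H](CO)[C@@H](O)[C@H]1O`: > 20000 nM
- Compound 2 `CNc1ncnc2c1c(-c1ccoc1)cn2[C@@H]1O[C@H](CO)[C@@H](O)[C@H]1O`: > 20000 nM
- Compound 3 `CNc1ncnc2c1c(-c1ccsc1)cn2[C@@H]1O[C@H](CO)[C@@H](O)[C@H]1O`: > 20000 nM

Compound 3 gives only a limit, > 20000 nM. It stands with the others at the limit of > 20000 nM in this assay, at which 3 of the 3 values shown sit. Compound 4 `CN(C)c1ncnc2c1c(-c1ccsc1)cn2[C@@H]1O[C@H](CO)[C@@H](O)[C@H]1O` changes methylamino to dimethylamino: methyl in place of hydrogen on a nitrogen on an aromatic ring. For the measured compounds named here, two measured steps touch compound 3: a step that the two limits leave unreadable from compound 1 to compound 3, and a step that the two limits leave unreadable from compound 2 to compound 3. Neither has a readable size, and neither is the same change, so they give no sign of activity appearing. No step beyond the scatter is expected in this assay, and another limit is the likeliest report. The estimated step is a step that the limit leaves unreadable from compound 3 to compound 4. Compound 4 is expected at 25000 nM, with an estimated range of 10000 nM to 50000 nM.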

Compound 4, half-maximal inhibitory concentration: > 20000 nM
Compound 4 ended at the assay's limit (the forecaster's own chance of this, stated with the estimate: 85%); the middle value is on the limit's open side.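

In this assay, compound 4 gives only a limit, as do compound 1 and compound 3, so neither step to compound 4 can be read: the limit of > 20000 nM in this assay, at which 4 of the 4 values shown sit. The compounds shown leave open which change, if any, would bring measurable inhibition.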